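A few compounds are considered here, and "the series" means these few. Any claim that something is new, unique, unknown or untested is made for them only; others in the source may bear on it.

Measured compounds:
- compound 1, `CCCCc1cn(C[C@H](O)[C@H]2OC(=O)C(OCc3ccccc3)=C2OCc2ccccc2)nn1`: 32800 nM in a functional assay on HepG2 cells (Homo sapiens) for antiproliferative activity, read by MTT assay, with a stated time of 72 h; on this read-out lower numbers stand for stronger inhibition and higher numbers for weaker inhibition
- compound 2, `CCCCCc1ccc(-c2cn(C[C@H](O)[C@H]3OC(=O)C(OCc4ccccc4)=C3OCc3ccccc3)nn2)cc1`: 7460 nM in this assay
- compound 3, `COc1ccccc1-c1cn(C[C@H](O)[C@H]2OC(=O)C(OCc3ccccc3)=C2OCc2ccccc2)nn1`: in this assay compound 3 reaches only the assay limit, > 100000 nM, and gives no number.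

Compound 3 thus sits at the weak end of the three, at the limit noted as the limit of > 100000 nM in this assay, at which 1 of the 3 values shown sits. Compound 4, `CCCCCCCCCCc1cn(C[C@H](O)[C@H]2OC(=O)C(OCc3ccccc3)=C2OCc2ccccc2)nn1`, carries the change (decyl in place of 2-methoxyphenyl on an aromatic carbon). Among the measured compounds shown here, two measured steps bear on this: the chain-to-aryl step an at least 3.0-fold higher number from compound 1 to compound 3 (0.48 log units; beyond the scatter) and the aryl-to-aryl step an at least 13-fold higher number from compound 2 to compound 3 (1.12 log units; beyond the scatter), both leading into the limit; the step of a 4.4-fold lower number from compound 1 to compound 2 (0.64 log units; beyond the scatter) shows that a longer group at this position can also help. Since compound 4 returns to a chain, a step the other way is expected in this assay, estimated as an at least 6.6-fold lower number from compound 3 to compound 4 (0.82 log units; beyond the scatter). Compound 4 is expected to give 15000 nM, between 4000 nM and 60000 nM.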

Compound 4, half-maximal inhibitory concentration: 12200 nM
Beside the measured number, compound 4's estimate is 1.2-fold (0.09 log units) above it; low and high end bracket the measured number.
By their numbers in this assay, from the lowest: compounds 2 and 4 (each within the scatter of the next); then compound 1. At a limit, above all of these: compound 3.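

In this assay an aryl ring is not required at this position: the step of a 1.6-fold higher number from compound 2 to compound 4 (0.21 log units; within the scatter) leaves decyl and 4-pentylphenyl indistinguishable. Chain length also matters, since going from butyl to decyl gives a 2.7-fold lower number from compound 1 to compound 4 (0.43 log units; beyond the scatter). The step of an at least 8.1-fold lower number from compound 3 to compound 4 (0.91 log units; beyond the scatter) starts from a limit of the assay rather than a number, so its true size is unknown: the limit of > 100000 nM in this assay, at which 1 of the 4 values shown sits.

From the compounds shown here alone, whether a longer chain such as dodecyl would lower the number further remains open, as does the effect of a chain ending in an amine or a carboxylic acid. Unsubstituted phenyl would show whether the methoxy group of compound 3 accounts for its standing.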